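The source may report more compounds than this note shows. Statements on the series, on what has been measured and on what is new or still open speak of the compounds shown alone.

Measured in a functional assay on HeLa cells (Homo sapiens) for antiproliferative activity, with a stated time of 48 h (on this read-out higher numbers stand for weaker inhibition and lower numbers for stronger inhibition), so far:
Compound 1 `C=C(Br)C(=O)Nc1ccc(/C=C/C(=O)c2ccc(Cl)cc2)cc1` gives 1600 nM 
Compound 2 `C=C(Br)C(=O)Nc1ccc(/C=C/C(=O)c2ccc(C)cc2)cc1` gives 2100 nM 

Compound 1 carries the lower of these two numbers, but not by more than the scatter, so it holds no real lead. Within the data shown here, the one measured step is small (a 1.3-fold higher number from compound 1 to compound 2 (0.12 log units; within the scatter)) and concerns methyl in place of chloro on an aromatic carbon. The next compound, compound 3 `Nc1ccc(/C=C/C(=O)c2ccc(Cl)cc2)cc1`, changes a different part of the molecule (hydrogen in place of (1-bromoethenyl)carbonyl on a nitrogen on an aromatic ring): hydrogen in place of (1-bromoethenyl)carbonyl on a nitrogen on an aromatic ring, which leaves an amino group. The measured step therefore says little about this change. Among the measured compounds shown here, both measured compounds carry the (1-bromoethenyl)carbonyl group, and no compound without it has been measured, so the size of the step rests on judgement alone. Since so much of the molecule goes, a step well beyond the scatter is expected, towards a higher number and so weaker inhibition. The estimated step is a 7.5-fold higher number from compound 1 to compound 3 (0.88 log units; beyond the scatter) in this assay and it remains uncertain. For compound 3 the expected value is 12000 nM within an estimated range of 3500 nM to 40000 nM in this assay as a rough guide.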

Compound 3, half-maximal inhibitory concentration: 43000 nM
Estimate against measurement, compound 3: 3.6-fold (0.55 log units) below; measured number outside the range, above it.
By their numbers in this assay, from the lowest: compounds 1 and 2 (each within the scatter of the next); then compound 3.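

Taking the (1-bromoethenyl)carbonyl off the nitrogen on the aromatic ring, which leaves an amino group, gives a large step in this assay, a 27-fold higher number from compound 1 to compound 3 (1.43 log units; beyond the scatter), whereas the earlier change of chloro to methyl on an aromatic carbon, a 1.3-fold higher number from compound 1 to compound 2 (0.12 log units; within the scatter), stayed within the scatter. Among these compounds, this is the first sign that the substituent on this nitrogen matters far more to the read-out than that earlier change, since the amino compound gives much weaker inhibition. Nothing available explains why the step is so large, and no other information on these compounds bears on it.

From the compounds shown here alone, it remains open how the step divides among the bromine, the double bond and the carbonyl: an acetyl or a plain propenoyl group on the same nitrogen could stay close to compound 1 at 1600 nM or move towards compound 3 at 43000 nM. Also open, going by these compounds, is whether methyl in place of chloro would still stay within the scatter on a compound that carries only the amino group.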